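This account rests on a few compounds, and the source may have more. Where it says the series, first, only, none or still open, it means among the compounds named here.

Compound 2 `Nc1cccc(S(=O)(=O)Oc2ccc(-c3cncn3C3CCN(C(=O)c4ccc(Cl)c(C(F)(F)F)c4)CC3)cc2)c1` gives 565 nM in an assay on HEK293 cells for antagonist activity at P2X purinoceptor 7 (Homo sapiens), read by fluorescence, with a stated time of 2 h; on this read-out higher numbers stand for weaker inhibition and lower numbers for stronger inhibition. Compound 1 `O=C(c1ccc(Cl)c(C(F)(F)F)c1)N1CCC(n2cncc2-c2ccc(OS(=O)(=O)c3ccccc3)cc2)CC1` gives 702 nM in this assay, and a 1.2-fold lower number from compound 1 to compound 2 (0.09 log units; within the scatter) places the two within the scatter of each other. Compound 3 `O=C(c1ccc(Cl)c(C(F)(F)F)c1)N1CCC(n2cncc2-c2ccc(OS(=O)(=O)c3cccc([N+](=O)[O-])c3)cc2)CC1` differs from compound 2 by nitro in place of amino on an aromatic carbon. For the measured compounds named here, the only measured step at this place, a 1.2-fold lower number from compound 1 to compound 2 (0.09 log units; within the scatter), stayed within the scatter, and no measured compound carries a nitro there, so no step beyond the scatter is expected in this assay. Compound 3 is therefore expected near 600 nM, within a range from 280 nM to 1300 nM, which would mean a step of a 1.1-fold higher number from compound 2 to compound 3 (0.03 log units; within the scatter).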

Compound 3, half-maximal inhibitory concentration: 249 nM
Beside the measured number, compound 3's estimate is 2.4-fold (0.38 log units) above it; the whole stated range lies above it.
By their numbers in this assay, from the lowest: compound 3; then compounds 2 and 1 (each within the scatter of the next).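

In this assay, this place on the ring now shows that it can respond to what it carries: the step of a 2.3-fold lower number from compound 2 to compound 3 (0.36 log units; beyond the scatter) and the step of a 2.8-fold lower number from compound 1 to compound 3 (0.45 log units; beyond the scatter) both lie beyond the scatter, whereas hydrogen and amino had stayed within it. The 3-nitrophenyl group thus sets compound 3 apart from both earlier compounds, though only modestly. No evidence available here bears on the reason for this difference.

Going by these compounds, whether a nitrile or a carboxylic acid at this place would give a similar number remains open. So does whether nitro would behave alike on another carbon of that ring.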